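Swapping the Aryl Group on a Tetraacetylglucosyl Enone

The source may report more compounds than this note shows. Statements on the series, on what has been measured and on what is new or still open speak of the compounds shown alone.

The series shares an acetylated sugar core carrying an unsaturated ketone side chain that ends in an aromatic group. For the measured compounds named here, compound 1 `CC(=O)OC[C@H]1O[C@@H](CC(=O)/C=C/c2cc(Cl)cc(Cl)c2)[C@H](OC(C)=O)[C@@H](OC(C)=O)[C@@H]1OC(C)=O` is the only member with a number in an ADME assay on cells (Epithelial cell, Homo sapiens) for cytotoxicity, read by MTT assay, with a stated time of 24 h (a higher number here means that more compound is tolerated, a lower number that less compound is tolerated), where compound 1 gives 32.9 nM. Compound 2 `COc1ccc(/C=C/C(=O)C[C@@H]2O[C@H](COC(C)=O)[C@@H](OC(C)=O)[C@H](OC(C)=O)[C@H]2OC(C)=O)cc1` was run in the same way, but for compound 2 the outcome is "not determined" (no result reported). Compound 3 `CC(=O)OC[C@H]1O[C@@H](CC(=O)/C=C/c2cccc3ccccc23)[C@H](OC(C)=O)[C@@H](OC(C)=O)[C@@H]1OC(C)=O` is in the same position: for compound 3 this assay reports "not determined" (no result reported), so compound 3 stands without a single number, alongside one further entry of the same kind.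

Compound 4 `CC(=O)OC[C@H]1O[C@@H](CC(=O)/C=C/c2cccc([N+](=O)[O-])c2)[C@H](OC(C)=O)[C@@H](OC(C)=O)[C@@H]1OC(C)=O` differs from compound 3 in a single place: 3-nitrophenyl in place of naphthalen-1-yl on a double-bonded chain carbon bound to a double-bonded chain carbon. Going by the values given here, no measured step covers this change, and nothing shows how much cytotoxicity shifts when the aromatic end of the chain is exchanged. Among the compounds with values here, the one number available, for compound 1, suggests that compounds of this shape are tolerated only at low concentrations. Compound 4 is therefore expected to give about 35 nM in this assay. The expected range for compound 4 runs from 8 nM to 150 nM, and no direction beyond the scatter is anticipated.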

Compound 4, half-maximal cytotoxic concentration: 15.5 nM
For compound 4 the middle estimate is 2.3-fold (0.35 log units) above the measured one; low and high end bracket the measured number.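

In this assay the aromatic end of the chain now shows a measurable effect: 3-nitrophenyl in place of 3,5-dichlorophenyl on a double-bonded chain carbon bound to a double-bonded chain carbon gives a 2.1-fold lower number from compound 1 to compound 4 (0.33 log units; beyond the scatter), so less compound is tolerated with the 3-nitrophenyl end. This single modest step shows that exchanging one substituted phenyl group for another at this position can move the read-out beyond the scatter. Nothing measured here explains the shift.

For the compounds shown here, with only two numbers, it remains open whether the step follows the arrival of the nitro group or the loss of the two chlorines, and where compound 2 and compound 3 would stand. Also open, from the compounds shown here alone, is how an amine or a carboxylic acid in place of the 3-nitrophenyl group would read in this assay.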